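The source may report more compounds than this note shows. Statements on the series, on what has been measured and on what is new or still open speak of the compounds shown alone.

- compound 1 `COc1cc(/C(F)=C/c2cc(O)c3ccsc3c2)cc(OC)c1OC`: 390 nM
- compound 2 `COc1ccc(/C(F)=C/c2cc(OC)c(OC)c(OC)c2)cc1O`: 26600 nM
- compound 3 `COc1ccc(/C(F)=C\c2cc(OC)c(OC)c(OC)c2)cc1O`: 4700 nM

In a functional assay on cells (Endothelial cell, Bos taurus) for antiproliferative activity (a higher number here means a weaker inhibitor, a lower number a stronger inhibitor), compound 3 holds the middle place of the three, with a higher number than compound 1 and a lower number than compound 2. Compound 4 `COc1ccc(/C(F)=C\c2cc(OC)c(OC)c(OC)c2)cc1N` carries amino in place of hydroxy on an aromatic carbon, ortho to a methoxy group: amino in place of hydroxy on an aromatic carbon. Among the compounds with values here, the only measured step, a 5.7-fold lower number from compound 2 to compound 3 (0.75 log units; beyond the scatter), is modest and reflects (the fact that compounds 2 and 3 differ only in the configuration as drawn), so it does not test this exchange and serves only as a loose gauge of size. No change beyond the scatter is therefore expected, and the direction remains uncertain. The estimated step is a 1.3-fold lower number from compound 3 to compound 4 (0.13 log units; within the scatter). Compound 4 is expected at about 3500 nM, within an estimated range of 700 nM to 16000 nM.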

Compound 4, half-maximal inhibitory concentration: 2100 nM
Compound 4: middle estimate off by 1.7-fold (0.22 log units), on the high side, and the stated range covers the measured number.
By their numbers in this assay, from the lowest: compound 1; then compound 4; then compound 3; then compound 2.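

In this assay, amino in place of hydroxy on this aromatic carbon, ortho to a methoxy group, brings a 2.2-fold lower number from compound 3 to compound 4 (0.35 log units; beyond the scatter). This is the first step shown that exchanges a group rather than the configuration as drawn, and it shows that this position accepts amino with a modest gain. Nothing given here explains the step.

Going by these compounds, whether an acetamido or dimethylamino group would go further at this position remains open. So does whether amino would bring a similar step with the double bond drawn Z.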